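The source may hold more compounds than are shown below. What is called first, only, known or untested is meant among the compounds shown, and "the series" means these compounds.

Measured so far in a physicochemical assay for lipophilicity, at pH 7.4; on this read-out higher numbers stand for higher lipophilicity and lower numbers for lower lipophilicity: compound 1 `Cc1cc(NC(=O)CC2CCCCC2)nn1Cc1cc(Cl)ccc1OCc1ccccc1` gives 3.2. Compound 2 `Cc1cc(NC(=O)C2CCOC2)nn1Cc1cc(Cl)ccc1OCc1ccccc1` gives only a limit of the assay, > 3.7.

Compound 2 therefore sits at the limit (the limit of > 3.7 in this assay, at which 1 of the 2 values shown sits), so its place among the numbers is a bound rather than a value. Compound 3 `Cc1cc(NC(=O)OCc2ccccn2)nn1Cc1cc(Cl)ccc1OCc1ccccc1` differs from it in one respect: (pyridin-2-yl)methoxy in place of oxolan-3-yl on a carbonyl carbon. Going by the values given here, the single measured step, a number at least 0.50 log units higher from compound 1 to compound 2 (beyond the scatter), concerns a different exchange on a carbonyl carbon and offers no direct guide. For compound 3 the step that the limit leaves unreadable from compound 2 to compound 3 is estimated as small, with the result likely again at or past the limit. Compound 3 is estimated at 3.9, between 3.3 and 4.5.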

Compound 3, distribution coefficient: 3.1
Beside the measured number, compound 3's estimate is 0.80 log units above it; the whole stated range lies above it.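

In this assay, putting (pyridin-2-yl)methoxy in place of oxolan-3-yl on the carbonyl carbon gives a number at least 0.60 log units lower from compound 2 to compound 3 (beyond the scatter). That size is only a bound, because compound 2 stands at a limit of the assay: the limit of > 3.7 in this assay, at which 1 of the 3 values shown sits. In place of cyclohexylmethyl, the same group gives a number 0.10 log units lower from compound 1 to compound 3 (within the scatter), so two very different groups at this position read alike, and only oxolan-3-yl stands apart.

The compounds shown leave open where compound 2 truly lies and whether the pyridine ring nitrogen matters to the reading. A benzyloxy group or an amine on the same carbonyl carbon would bear on the second question.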